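The source may hold more compounds than are shown below. What is called first, only, known or untested is meant among the compounds shown, and "the series" means these compounds.

Measured compounds:
- compound 1 `CCCOc1cc(=O)oc2cc(OCc3cccc(F)c3)ccc12`: 12% in an assay on isolated protein (strain Sprague-Dawley) for inhibition of Amine oxidase [flavin-containing] A (Rattus norvegicus), read by spectrophotometry, with a stated time of 5 min, tested at 10 uM; a lower number here means less inhibition, a higher number more inhibition at the concentration tested (going by the name of the read-out)
- compound 2 `CC(C)Oc1cc(=O)oc2cc(OCc3cccc(Cl)c3)ccc12`: 3% in this assay

Compound 2 gives the lowest of the two numbers recorded in this assay, but its nearest neighbour, compound 1, sits only a little higher, and that gap lies within the scatter of the method, so the two compounds cannot be told apart on these values. Both show only a small fraction of inhibition at the concentration tested.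

Compound 3 `NC(=O)c1cc(=O)oc2cc(OCc3cccc(Cl)c3)ccc12` is the next compound to be measured in this assay. It differs from compound 2 in one place: carbamoyl in place of isopropoxy on an aromatic carbon. Among the compounds with values here, no step between measured compounds shows what this kind of exchange does, so the expectation rests on the low readings of compound 2 and compound 1 alone.

Compound 3 is expected to stay in the same weak region, with a step of a number 5 percentage points higher from compound 2 to compound 3 (within the scatter) that is not expected to exceed the scatter in either direction. The estimate for compound 3 in this assay is 8%, with a range from 0% to 25%.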

Compound 3, a percentage reported as inhibition, at one concentration (the size of the read-out at that concentration, not a potency): 14%
For compound 3 the middle estimate is 6 percentage points below the measured one; the range from low to high includes it.
By their numbers in this assay, from the lowest: compounds 2, 1 and 3 (each within the scatter of the next, the first and the last beyond it).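

In this assay, within the data shown here, carbamoyl in place of isopropoxy on an aromatic carbon, opposite the ring oxygen, gives a number 11 percentage points higher from compound 2 to compound 3 (beyond the scatter), the first step that can be read at this position. The reading at this position therefore responds to the exchange of one group, with the rest of the core held the same, although compound 3 still shows only 14% at the concentration tested. Nothing available accounts for the step, so its cause remains unknown.

The compounds shown leave open whether a carboxylic acid, an amine or a longer alkoxy chain at this position would read differently from carbamoyl. They also leave open whether the same exchange would give a similar step with fluorine rather than chlorine on the benzyl ether.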